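A few compounds are considered here, and "the series" means these few. Any claim that something is new, unique, unknown or untested is made for them only; others in the source may bear on it.

Of the compounds shown here, three share a core and have been tested in a functional assay on CHO cells for agonist activity at Free fatty acid receptor 1 (Homo sapiens), read by FLIPR and calcium flux; a lower number here means that less compound is needed, a higher number that more compound is needed for the effect. Compound 1 `COCCOc1cc(C)c(-c2cccc(CNc3ccc(OCC(=O)O)c(F)c3)c2)c(C)c1` gives 51.6 nM. Compound 2 `Cc1cc(OCCCS(C)(=O)=O)cc(C)c1-c1cccc(CNc2ccc(OCC(=O)O)c(F)c2)c1`, which differs from compound 1 only by the change from compound 1 to compound 2 of a 1.2-fold higher number from compound 1 to compound 2 (0.06 log units; within the scatter), gives 59.8 nM. Compound 3 `O=C(O)COc1ccc(NCc2cccc(-c3ccccc3F)c2)cc1F` gives 36.5 nM, the lowest of the three numbers, although its gaps to compound 1 and compound 2 both lie within the scatter, so the three compounds cannot be ranked.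

Compound 4 `Cc1ccccc1-c1cccc(CNc2ccc(OCC(=O)O)c(F)c2)c1` differs from compound 3 by methyl in place of fluoro on an aromatic carbon, that is, 2-fluorophenyl becomes 2-methylphenyl, ortho to a large group. Within the data shown here, no measured pair shows this exchange; the only measured step, from compound 1 to compound 2, alters a chain on the other side of the molecule and stays within the scatter. There is thus no basis for expecting a shift beyond the scatter in this assay, and the step of a 1.1-fold higher number from compound 3 to compound 4 (0.04 log units; within the scatter) is estimated as essentially flat. Compound 4 is therefore expected to give about 40 nM, in a range from 15 nM to 110 nM.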

Compound 4, half-maximal effective concentration: 4.8 nM
Beside the measured number, compound 4's estimate is 8.3-fold (0.92 log units) above it; the measured number lies below the stated range.
By their numbers in this assay, from the lowest: compound 4; then compounds 3, 1 and 2 (each within the scatter of the next).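

In this assay, exchanging 2-fluorophenyl for 2-methylphenyl gives a 7.6-fold lower number from compound 3 to compound 4 (0.88 log units; beyond the scatter), the only step shown that lies beyond the scatter. The change is small on paper, with one heavy atom replacing another and neither group carrying a hydrogen-bond donor, an acceptor or a net charge, yet this position on the aromatic ring responds clearly, whereas the chain change in a 1.2-fold higher number from compound 1 to compound 2 (0.06 log units; within the scatter) left the number within the scatter. Nothing measured here explains why methyl and fluoro differ so much at this position.

As far as these compounds go, only fluoro and methyl are seen at this place, so it remains open how chloro, ethyl or methoxy would compare there. From the compounds shown here alone, it is also open whether the same exchange would give a step of similar size in compounds carrying the chains of compound 1 and compound 2.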